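Swapping the pyrrole for a phenyl ring on the acrylonitrile

A few compounds are considered here, and "the series" means these few. Any claim that something is new, unique, unknown or untested is made for them only; others in the source may bear on it.

Measured compounds:
- compound 1, `N#C/C(=C\c1ccc[nH]1)C(=O)NCc1ccc(Cl)c(Cl)c1`: 85000 nM
- compound 2, `COc1ccc(CNC(=O)/C(C#N)=C/c2ccc(Cl)o2)cc1`: 9000 nM

Both compounds were tested in a functional assay on HT-29 cells (Homo sapiens) for inhibition, read by MTT assay, with a stated time of 72 h; on this read-out higher numbers stand for weaker inhibition of growth and lower numbers for stronger inhibition of growth. Compound 1 gives 85000 nM, the highest of the two numbers, while compound 2 gives 9000 nM, a markedly lower number, beyond the scatter. Compound 2 differs from compound 1 in more than one place, so its value only shows that another member of this family reaches a clearly stronger effect.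

Compound 3, `N#C/C(=C\c1ccccc1)C(=O)NCc1ccc(Cl)c(Cl)c1`, has not been measured in this assay. It is built from compound 1 by a single change: phenyl in place of 1H-pyrrol-2-yl on a double-bonded chain carbon bound to a double-bonded chain carbon. Among the measured compounds shown here, no pair of measured compounds differs in this way alone, so there is no measured step to lean on. The change removes the one hydrogen-bond donor of the ring on the double-bonded chain carbon and replaces it with a plain carbon ring. With compound 1 already among the weakest numbers here, the step from compound 1 to compound 3 is expected to be small, a 1.2-fold lower number from compound 1 to compound 3 (0.08 log units; within the scatter), with no clear direction beyond the scatter. Compound 3 is therefore estimated to give about 70000 nM, in a range from 20000 nM to 200000 nM.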

Compound 3, concentration for 50% growth inhibition: 70000 nM
The estimate for compound 3 equals the measured number at the digits printed, within the range that was stated.
By their numbers in this assay, from the lowest: compound 2; then compounds 3 and 1 (each within the scatter of the next).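

In this assay, among the compounds shown here, phenyl in place of 1H-pyrrol-2-yl on a double-bonded chain carbon bound to a double-bonded chain carbon gives a 1.2-fold lower number from compound 1 to compound 3 (0.08 log units; within the scatter) and so provides the first direct comparison at this position, where the two rings cannot be told apart. The change removes the ring nitrogen and the one hydrogen-bond donor of the ring, yet the two numbers stay within the scatter of each other, so in this pair that donor makes no measurable difference to the read-out. No measurement of any property of these compounds bears on this result, and the pair alone gives no explanation for it.

The compounds shown leave open whether a pyridine ring at this position, or a phenyl ring carrying an amine or a carboxylic acid, would move the number beyond the scatter. From the compounds shown here alone, this is also a single step on the core of compound 1, so it remains unknown whether the same ring swap would stay as small with a different group on the amide nitrogen.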